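Removing the Last Chloro: Expectation for Compound 4

The source may hold more compounds than are shown below. What is called first, only, known or untested is meant among the compounds shown, and "the series" means these compounds.

Compound 3 `N/C(=N/NC(CC(=O)c1ccc(-n2ccnc2)cc1)c1ccc(Cl)cc1)c1ccccn1` stands highest of the three measured compounds in an ADME assay on Vero cells (Chlorocebus sabaeus) for cytotoxicity, read by MTT assay, with a stated time of 72 h; a higher number here means that more compound is tolerated, a lower number that less compound is tolerated. In this assay compound 3 gives 78800 nM. Compound 1 `N/C(=N/NC(CC(=O)c1ccc(-n2ccnc2)cc1)c1ccc(Cl)cc1Cl)c1ccccn1` gives 27800 nM, and compound 2 `N/C(=N/NC(CC(=O)c1ccc(-n2ccnc2)cc1)c1ccc([N+](=O)[O-])cc1)c1ccccn1` gives 23100 nM. Two steps lead up to compound 3: a 2.8-fold higher number from compound 1 to compound 3 (0.45 log units; beyond the scatter), and a 3.4-fold higher number from compound 2 to compound 3 (0.53 log units; beyond the scatter). Between the other two, a 1.2-fold lower number from compound 1 to compound 2 (0.08 log units; within the scatter), so the two chlorines and the nitro group leave the number in much the same place.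

Compound 4 `N/C(=N/NC(CC(=O)c1ccc(-n2ccnc2)cc1)c1ccccc1)c1ccccn1` has not yet been measured. The change from compound 3 is hydrogen in place of chloro on an aromatic carbon. Within the data shown here, the one measured step of the same kind, a 2.8-fold higher number from compound 1 to compound 3 (0.45 log units; beyond the scatter), also took a chloro off an aromatic carbon and produced a modest rise in tolerated concentration. On that basis a step of similar size and direction is expected here: a 1.5-fold higher number from compound 3 to compound 4 (0.18 log units; within the scatter). Among the measured compounds shown here, only one such step is known, and the rise in a 2.8-fold higher number from compound 1 to compound 3 (0.45 log units; beyond the scatter) was modest. A result within the scatter of compound 3 therefore cannot be excluded. Compound 4 is therefore estimated at 120000 nM, with a range from 55000 nM to 260000 nM.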

Compound 4, half-maximal cytotoxic concentration: 63500 nM
Compound 4: the middle estimate sits 1.9-fold (0.28 log units) above what was measured, within the range that was stated.
By their numbers in this assay, from the lowest: compounds 2 and 1 (each within the scatter of the next); then compounds 4 and 3 (each within the scatter of the next).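

In this assay, the 4-chlorophenyl to phenyl change leaves the number in place (a 1.2-fold lower number from compound 3 to compound 4 (0.09 log units; within the scatter)), so the rise seen in the earlier hydrogen-for-chloro step (a 2.8-fold higher number from compound 1 to compound 3 (0.45 log units; beyond the scatter)) does not carry over to this aromatic carbon, para to a large group. The phenyl compound also stands clear of the nitro compound (a 2.7-fold higher number from compound 2 to compound 4 (0.44 log units; beyond the scatter)) and of the 2,4-dichlorophenyl compound (a 2.3-fold higher number from compound 1 to compound 4 (0.36 log units; beyond the scatter)), so among these four compounds, compounds 3 and 4 form an upper pair and compounds 1 and 2 a lower one, with no compound going against that split. Nothing measured here gives a reason for either the absence of a change at this position or the gap between the two pairs.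

Only hydrogen, chloro and nitro stand at this position in the compounds shown, so it remains open whether a methoxy group, an amine or a carboxylic acid there would stay with the upper pair or join compound 2. On these data alone, all four compounds also share the same core, so it remains open whether these steps would hold with a longer chain leading to the carbonyl.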